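Para Substituent Swap on an Aryl Isoxazoline Lactone Scaffold

This account rests on a few compounds, and the source may have more. Where it says the series, first, only, none or still open, it means among the compounds named here.

Measured compounds:
compound 1, `C[C@H]1CC[C@@H]2[C@@H](OC(=O)[C@]23CC(c2ccc(Cl)cc2)=NO3)[C@]2(C)C(=O)C=C[C@@]12O`, 43000 nM
compound 2, `C[C@H]1CC[C@@H]2[C@@H](OC(=O)[C@]23CC(c2ccc(N(C)C)cc2)=NO3)[C@]2(C)C(=O)C=C[C@@]12O`, 4500 nM

Going by the values given here, in a functional assay on DU-145 cells (Homo sapiens) for cytotoxicity, read by sulforhodamine B assay, with a stated time of 48 h (a lower number here means a stronger inhibitor, a higher number a weaker inhibitor), compound 2 gives 4500 nM, the lowest of the two numbers measured so far, while compound 1 gives 43000 nM. Among the compounds with values here, the single measured step, a 9.6-fold lower number from compound 1 to compound 2 (0.98 log units; beyond the scatter), is the only one that bears on the change now considered, and it shows that exchanging the group at this position of the aromatic ring can shift the read-out well beyond the scatter. Compound 3, `C[C@H]1CC[C@@H]2[C@@H](OC(=O)[C@]23CC(c2ccc([N+](=O)[O-])cc2)=NO3)[C@]2(C)C(=O)C=C[C@@]12O`, carries the change (nitro in place of dimethylamino on an aromatic carbon). Within the data shown here, since the nitro group is a different group again, and no measured pair shows what it does, the direction is uncertain; the one step available suggests a move back toward the weaker side is plausible. Compound 3 is therefore expected to show a 4.4-fold higher number from compound 2 to compound 3 (0.65 log units; beyond the scatter), giving an estimated 20000 nM with a range from 5000 nM to 60000 nM.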

Compound 3, half-maximal inhibitory concentration: 7000 nM
Estimate against measurement, compound 3: 2.9-fold (0.46 log units) above, and the stated range covers the measured number.
By their numbers in this assay, from the lowest: compounds 2 and 3 (each within the scatter of the next); then compound 1.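

In this assay the change from dimethylamino to nitro on this aromatic carbon gives a 1.6-fold higher number from compound 2 to compound 3 (0.19 log units; within the scatter) and so cannot be told apart from no change at all, which the single earlier step could not have shown. Chloro now stands alone, since the step of a 6.1-fold lower number from compound 1 to compound 3 (0.79 log units; beyond the scatter) puts nitro with dimethylamino on the same side of compound 1, so two quite different groups here give numbers within the scatter of each other. Nothing available explains why these two groups read alike or why chloro differs.

Three groups at one place cannot show whether chloro is the exception or whether other groups would also fall with it. A simple amine, a methoxy group or a carboxylic acid at this position could help to settle that.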